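Methyl in place of trifluoromethyl on an aromatic carbon

The source may hold more compounds than are shown below. What is called first, only, known or untested is meant among the compounds shown, and "the series" means these compounds.

In a functional assay on NCI-H460 cells (Homo sapiens) for inhibition, read by MTT assay, with a stated time of 24 h, tested at 1 ug/mL (on this read-out higher numbers stand for more inhibition of growth at the one concentration tested and lower numbers for less inhibition of growth), compound 1 `O=C(CCCCC(S)CCS)Nc1cccc(Cl)c1` gives 7.2% and compound 2 `O=C(CCCCC(S)CCS)Nc1cccc(C(F)(F)F)c1` gives 8.26%. For the measured compounds named here, compound 2 therefore stands within the scatter of compound 1, the only other compound measured. Compound 3 `Cc1cccc(NC(=O)CCCCC(S)CCS)c1` differs from compound 2 by methyl in place of trifluoromethyl on an aromatic carbon. Going by the values given here, one measured step bears on this change: a number 1.1 percentage points higher from compound 1 to compound 2 (within the scatter), with trifluoromethyl in place of chloro. No step beyond the scatter is therefore expected, and the expected step is a number 0.3 percentage points lower from compound 2 to compound 3 (within the scatter). The estimate for compound 3 is 8%, with an estimated range of 1% to 16%.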

Compound 3, percent growth inhibition at one concentration: 9.43%
Compound 3: the middle estimate sits 1.4 percentage points below what was measured; low and high end bracket the measured number.
By their numbers in this assay, from the lowest: compounds 1, 2 and 3 (each within the scatter of the next).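

In this assay, with the group on an aromatic carbon of a six-membered aromatic ring of carbon only, meta to a large group, methyl in place of trifluoromethyl gives a number 1.2 percentage points higher from compound 2 to compound 3 (within the scatter) and methyl in place of chloro gives a number 2.2 percentage points higher from compound 1 to compound 3 (within the scatter). Trifluoromethyl has 4 heavy atoms and methyl has 1 heavy atom. The read-out for these two groups and chloro stays within the scatter. Nothing at hand speaks to why these three groups read alike.

From the compounds shown here alone, whether an amine or a carboxylic acid at this place would move the number remains open. So does whether any group here lifts growth inhibition clear of these three compounds.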